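The compounds below may be only part of what the source reports. "The series", "measured", "known", "first", "only" and "open" are said of these compounds alone.

Measured in a functional assay (strain AB) with Danio rerio as the target, read by microscopy, with a stated time of 1 h; on this read-out lower numbers stand for an effect already at smaller amounts and higher numbers for an effect only at larger amounts of compound:
- compound 1 `CCN1CCc2c(sc(NC(=O)Nc3ccccc3)c2C(N)=O)C1`: > 25000 nM (a limit)
- compound 2 `CCN1CCc2c(sc(NC(=O)CN3CCCCC3)c2C(N)=O)C1`: > 25000 nM (a limit)

Compound 2 has no numerical value, only the limit > 25000 nM in this assay. Among the compounds with values here, the series so far rests on (the limit of > 25000 nM in this assay, at which 2 of the 2 values shown sit).

The next change leads to compound 3 `CCN1CCc2c(sc(NC(=O)[C@@H]3CCCN3)c2C(N)=O)C1`: pyrrolidin-2-yl in place of (piperidin-1-yl)methyl on a carbonyl carbon. Pyrrolidin-2-yl replaces (piperidin-1-yl)methyl on a carbonyl carbon, and the entering group brings 1 defined stereocentre.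

Within the data shown here, the one measured step that bears on this is a step that the two limits leave unreadable from compound 1 to compound 2. It also changes the group on the carbonyl carbon, but it offers no size to carry over. No step beyond the scatter is therefore expected in this assay, in either direction, and another limit is the likeliest result. The expected step is a number no higher from compound 2 to compound 3 (the limit leaves the size open). Compound 3 is estimated at 25000 nM, with an expected range of 6000 nM to 40000 nM.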

Compound 3, half-maximal effective concentration: > 25000 nM
Compound 3: no number, only a limit; the forecaster's own chance of this, stated with the estimate: 70%; the middle value lies on the limit itself.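

In this assay compound 3 gives > 25000 nM, a limit and not a number, so no step can be read among compound 1, compound 2 and compound 3. The compounds shown leave open whether any group on the carbonyl carbon gives a numerical half-maximal effective concentration in this assay.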